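The compounds below may be only part of what the source reports. "The series", "measured", "known", "first", "only" and "open" are said of these compounds alone.

Measured so far:
Compound 1, `CCCCCCCc1cc2c(=O)n(CC3CC3)cnc2s1`: > 100 ug/mL
Compound 2, `CCCCCCc1cc2c(=O)n(CCN=[N+]=[N-])cnc2s1`: 16.2 ug/mL

In an ADME assay on A549 cells (Homo sapiens) for cytotoxicity, read by MTT assay, with a stated time of 11 days (on this read-out lower numbers stand for stronger inhibition of growth and higher numbers for weaker inhibition of growth), compound 2 gives 16.2 ug/mL, the only actual number among the two results shown. For compound 1 the result > 100 ug/mL is a limit of the assay and not a number, so compound 1 sits at the limit of > 100 ug/mL in this assay, at which 1 of the 2 values shown sits. Within the data shown here, no two measured compounds differ in a single place, so there is no measured step to lean on. Compound 3, `CCCCCCCc1cc2c(=O)n(CCN=[N+]=[N-])cnc2s1`, is not yet measured; it differs from compound 2 by methyl in place of hydrogen on a saturated chain carbon, six bonds along the chain from an aromatic carbon, which simply lengthens the saturated chain by one link. For such a small change the expectation in this assay is a step of no size beyond the usual scatter, in either direction. Compound 3 is therefore expected to give 13 ug/mL, with a range from 5 ug/mL to 40 ug/mL. The step this estimate means, a 1.2-fold lower number from compound 2 to compound 3 (0.10 log units; within the scatter), is expected to stay within the scatter.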

Compound 3, concentration for 50% growth inhibition: > 100 ug/mL
Compound 3: a limit, no number; the forecaster's own chance of this, stated with the estimate: 10%; middle value at least 7.6-fold (0.88 log units) from the limit.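

In this assay, this position turns out to be sensitive: lengthening the saturated chain by one link, with methyl in place of hydrogen six bonds along the chain from an aromatic carbon, gives an at least 6.1-fold higher number from compound 2 to compound 3 (0.79 log units; beyond the scatter). The result for compound 3, > 100 ug/mL, is a limit of the assay and not a number, so the step has a printed minimum but no known full size. The step that swaps cyclopropyl for azidomethyl cannot be read, because the results for both compound 1 and compound 3 are limits: the limit of > 100 ug/mL in this assay, at which 2 of the 3 values shown sit.

The compounds shown leave open whether a shorter chain, such as butyl, would give a lower number than compound 2. Also open, on these data alone, is whether an amine in place of the azido group would bring a measurable number back to the longer chain.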